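The compounds below may be only part of what the source reports. "The series", "measured", "known", "first", "only" and "open" are said of these compounds alone.

Measured so far:
Compound 1 `COc1ccccc1N1CCN(CCCCCOc2c(Br)cc(Br)cc2Oc2ccc(Br)cc2Br)CC1` — 32.2 ug/mL
Compound 2 `Brc1ccc(Oc2cc(Br)cc(Br)c2OCCCCCN2CCN(C/C=C/c3ccccc3)CC2)c(Br)c1` — 47.2 ug/mL
Compound 3 `BrCCCOc1c(Br)cc(Br)cc1Oc1ccc(Br)cc1Br` — 29.9 ug/mL

In a functional assay on HL-60 cells (Homo sapiens) for cytotoxicity, read by MTT assay, with a stated time of 24 h (on this read-out higher numbers stand for weaker inhibition and lower numbers for stronger inhibition), the three measured compounds sit close together. Compound 2 gives 47.2 ug/mL, and its gaps to compound 1 and to compound 3 are both within the usual scatter, so no order among the three can be read from these numbers.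

Compound 4 `CC(C)(C)OC(=O)N1CCN(CCCCCOc2c(Br)cc(Br)cc2Oc2ccc(Br)cc2Br)CC1` is the next compound to be measured in this assay. It differs from compound 2 at one place: tert-butoxycarbonyl in place of 3-phenylprop-2-en-1-yl on an amine nitrogen in a ring. Within the data shown here, the one measured step that bears on this change is the exchange at the same ring nitrogen, a 1.5-fold higher number from compound 1 to compound 2 (0.17 log units; within the scatter), which was within the scatter. The shared core of compounds 1, 2 and 3 also gives numbers that stay within the scatter of one another across quite different groups. On that basis the step of a 1.2-fold lower number from compound 2 to compound 4 (0.07 log units; within the scatter) is expected to stay within the scatter. Compound 4 is therefore estimated at 40 ug/mL, with a range from 20 ug/mL to 80 ug/mL.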

Compound 4, half-maximal inhibitory concentration: 32.1 ug/mL
For compound 4 the middle estimate is 1.2-fold (0.10 log units) above the measured one; the range from low to high includes it.
By their numbers in this assay, from the lowest: compounds 3, 4, 1 and 2 (each within the scatter of the next).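

In this assay, tert-butoxycarbonyl on the ring nitrogen gives a 1.5-fold lower number from compound 2 to compound 4 (0.17 log units; within the scatter) and a 1.0-fold lower number from compound 1 to compound 4 (0.00 log units; within the scatter), both within the scatter. Among these compounds, the earlier step at this nitrogen compared only two groups that each carry a ring, whereas this group has no ring and brings two hydrogen-bond acceptors, yet no difference can be read among the three groups. No measurement at hand explains why these exchanges leave the number within the scatter.

Going by these compounds, it remains open whether any group at this nitrogen can move the number beyond the scatter, such as a free amine hydrogen or an acetic acid group carrying a carboxylic acid. On these data alone, it is also open whether a longer chain between the shared core and the ring would do so.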